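Phenyl for Methyl on a Saturated Ring Carbon

A few compounds are considered here, and "the series" means these few. Any claim that something is new, unique, unknown or untested is made for them only; others in the source may bear on it.

Measured compounds:
Compound 1, `CC1CCN(c2nc(-c3ccccc3)nc3ccccc23)CC1`: 69%
Compound 2, `c1ccc(-c2nc(N3CCC(c4ccccc4)CC3)c3ccccc3n2)cc1`: 85.3%
Compound 3, `CC1CCN(c2nc(-c3ccc(Cl)cc3)nc3ccc(I)cc23)CC1`: 45.8%

All three were tested in a functional assay on the whole organism for inhibition, with Rattus norvegicus as the target, read by paw edema, with stated times of 4 days, 1 h and 2 h, at a dose of 100 mg/kg by the oral route; on this read-out higher numbers stand for more inhibition at the one dose given (going by the name of the read-out) and lower numbers for less inhibition. In this assay compound 2 gives 85.3%, compound 1 gives 69%, and compound 3 gives 45.8%, the lowest of the three; its distance to compound 1 and to compound 2 lies beyond the usual scatter.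

Compound 1 and compound 2 differ in one place: phenyl in place of methyl on a saturated ring carbon. This change gave a number 16.3 percentage points higher from compound 1 to compound 2 (beyond the scatter), a modest gain.

Compound 4, `Clc1ccc(-c2nc(N3CCC(c4ccccc4)CC3)c3cc(I)ccc3n2)cc1`, has not yet been measured. It is related to compound 3 by the same change: phenyl in place of methyl on a saturated ring carbon. The two place descriptions match word for word, so this is the same change, made on a different core. The difference between the core of compound 3 and the core of compound 1 is not broken down here, so the change appears twice among the compounds shown, once measured and once not.

Compound 4 is expected to gain about a number 16.2 percentage points higher from compound 3 to compound 4 (beyond the scatter) in this assay, because the same change gave a number 16.3 percentage points higher from compound 1 to compound 2 (beyond the scatter) on the other core. Compound 4 is therefore estimated at 62%, with the likely range running from 46% to 78%. Among the compounds with values here, the single measured example of this change is the only support for that expectation.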

Compound 4, a percentage reported as inhibition, in the whole organism at one dose (the size of the read-out at that dose, not a potency): 41.4%
Estimate against measurement, compound 4: 20.6 percentage points above; the measured number lies below the stated range.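

In this assay, phenyl in place of methyl on a saturated ring carbon did not behave the same way on the two cores: the same change on two cores in this assay, a number 16.3 percentage points higher (beyond the scatter) from compound 1 to compound 2 and a number 4.4 percentage points lower (within the scatter) from compound 3 to compound 4, 20.7 percentage points apart, beyond the scatter of two such steps. On the core of compound 3 the step reads a number 4.4 percentage points lower from compound 3 to compound 4 (within the scatter), so the swap there cannot be told apart from the ordinary spread of repeat measurements, and the gain seen on the core of compound 1 cannot be treated as a rule for the whole series. Within the data shown here, this does not show why the two cores respond differently, since they differ in more than one place and only two pairs of compounds carry this change, and a reading at one dose says nothing about potency.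

The compounds shown leave open whether the chlorine on the phenyl group, the iodine on the fused ring system, or the two together separate the core of compound 3 from the core of compound 1, which a compound carrying only one of these atoms could help to settle. They also leave open how the two cores would respond to other groups on that same saturated ring carbon, such as an amine, a carboxylic acid or a longer chain.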